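This account rests on a few compounds, and the source may have more. Where it says the series, first, only, none or still open, it means among the compounds named here.

Working notes on the series. In a functional assay on HCC 2998 cells (Homo sapiens) for inhibition, read by sulforhodamine B assay, with a stated time of 48 h (a lower number here means a stronger inhibitor of growth, a higher number a weaker inhibitor of growth), compound 1 `COc1cc(-c2cc(/C=C/C(=O)c3ccc(N)cc3)[nH]n2)cc(OC)c1OC` gives 2010 nM. Among the compounds with values here, the only other number in hand comes from compound 2 `COc1ccc(-c2cc(/C=C/C(=O)c3ccc(N)cc3)[nH]n2)cc1OC`, which gives 2020 nM; the step of a 1.0-fold higher number from compound 1 to compound 2 (0.00 log units; within the scatter), hydrogen in place of methoxy on an aromatic carbon, is within the scatter, so neither compound stands apart from the other in this assay. Compound 3 `COc1ccc(C(=O)/C=C/c2cc(-c3cc(OC)c(OC)c(OC)c3)n[nH]2)cc1OC` is not yet measured. It differs from compound 1 as follows: 3,4-dimethoxyphenyl in place of 4-aminophenyl on a carbonyl carbon. Within the data shown here, no measured step bears on a change at the carbonyl carbon; the single step in hand concerns a different ring and was within the scatter. There is thus no basis for expecting a step beyond the scatter in this assay in either direction, and the range is kept wide. The step expected is a 1.0-fold lower number from compound 1 to compound 3 (0.00 log units; within the scatter). Compound 3 is estimated at 2000 nM, with a range from 600 nM to 7000 nM.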

Compound 3, concentration for 50% growth inhibition: 2130 nM
Compound 3: the middle estimate sits 1.1-fold (0.03 log units) below what was measured; the measured number falls inside the stated range.
By their numbers in this assay, from the lowest: compounds 1, 2 and 3 (each within the scatter of the next).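

In this assay the group on the carbonyl carbon now has a measured change: the step of a 1.1-fold higher number from compound 1 to compound 3 (0.03 log units; within the scatter) shows 3,4-dimethoxyphenyl and 4-aminophenyl giving numbers within the scatter of each other on this core. For this pair, the amine is not needed to keep a number of this size, and an aromatic ring without it serves equally well at this position. No measurement at hand gives a reason for this flat result.

On these data alone, it remains open whether a group on the carbonyl carbon that is not an aromatic ring, such as a carboxylic acid or a longer alkyl chain, would move the number beyond the scatter. As far as these compounds go, it is also open whether 3,4-dimethoxyphenyl at this position would give a similar number with the other aryl group of compound 2.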